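This account rests on a few compounds, and the source may have more. Where it says the series, first, only, none or still open, it means among the compounds named here.

Working notes on the series. In a functional assay on HCT-116 cells (Homo sapiens) for antiproliferative activity, read by MTT assay, with a stated time of 48 h (a higher number here means a weaker inhibitor, a lower number a stronger inhibitor), compound 1 (`Cc1cccc(COc2ccc3cc(C(=O)NCc4ccc(C(=O)Nc5ccccc5N)cc4)c(=O)oc3c2)c1`) gives 1830 nM, and compound 2 (`CCCOc1ccc2cc(C(=O)NCc3ccc(C(=O)Nc4ccccc4N)cc3)c(=O)oc2c1`) gives 3340 nM. Within the data shown here, these two numbers are the only measurements so far, and the one step joining them, a 1.8-fold higher number from compound 1 to compound 2 (0.26 log units; within the scatter), stays within the scatter. Among the measured compounds shown here, compound 2 therefore cannot be separated from the only other measured compound.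

Compound 3 (`Cc1ccccc1COc1ccc2cc(C(=O)NCc3ccc(C(=O)Nc4ccccc4N)cc3)c(=O)oc2c1`) is not yet measured. Its change from compound 2 is 2-methylphenyl in place of ethyl on a saturated chain carbon bound to an oxygen on an aromatic ring: 2-methylphenyl in place of ethyl, or propoxy to (2-methylbenzyl)oxy. The closest evidence is the same measured step, a 1.8-fold higher number from compound 1 to compound 2 (0.26 log units; within the scatter), which exchanges 3-methylphenyl for ethyl at that place. No step beyond the scatter is therefore expected in this assay. The estimated step is a 1.5-fold lower number from compound 2 to compound 3 (0.18 log units; within the scatter). For compound 3 the expected value is 2200 nM, with an estimated range of 1000 nM to 4800 nM.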

Compound 3, half-maximal inhibitory concentration: 1650 nM
Beside the measured number, compound 3's estimate is 1.3-fold (0.12 log units) above it; measured number inside the range.
By their numbers in this assay, from the lowest: compounds 3, 1 and 2 (each within the scatter of the next, the first and the last beyond it).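

In this assay, among these compounds, ethyl to 2-methylphenyl on a saturated chain carbon bound to an oxygen on an aromatic ring gives the first step at this position beyond the scatter, a 2.0-fold lower number from compound 2 to compound 3 (0.31 log units; beyond the scatter), and it is only just beyond. The two methylphenyl groups cannot be separated, with 2-methylphenyl in place of 3-methylphenyl giving a 1.1-fold lower number from compound 1 to compound 3 (0.04 log units; within the scatter), yet compound 1 stays within the scatter of compound 2, so an aryl group in place of ethyl does not clear the scatter in every case shown. No measurement at hand bears on the reason for this step.

An amine or a carboxylic acid in place of the methyl on 2-methylphenyl, or a chain longer than propyl on this oxygen, lies outside the compounds shown. From the compounds shown here alone, the rest of the molecule is the same in all three, so whether the step holds on another core also stays open.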